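Diaryl urea series: dichlorophenyl variant of compound 2

This account rests on a few compounds, and the source may have more. Where it says the series, first, only, none or still open, it means among the compounds named here.

Compound 1 `Cc1cc(C)nc(Oc2ccc(NC(=O)Nc3ccc(OC(F)(F)F)cc3)cc2)n1`: in a functional assay on MGC-803 cells (Homo sapiens) for cytotoxicity, read by MTT assay, with a stated time of 3 days (a higher number here means a weaker inhibitor, a lower number a stronger inhibitor), compound 1 sits at the assay limit, > 50000 nM.
Compound 2 `Cc1cc(C)nc(Oc2ccc(NC(=O)Nc3ccc(F)cc3)cc2)n1`: in this assay compound 2 sits at the assay limit, > 50000 nM.

Compound 2 stands only as a limit, so its place next to compound 1 cannot be read; the step that the two limits leave unreadable from compound 1 to compound 2 says as much. Compound 3 `Cc1cc(C)nc(Oc2ccc(NC(=O)Nc3ccc(Cl)cc3Cl)cc2)n1` differs from compound 2 by 2,4-dichlorophenyl in place of 4-fluorophenyl on an amide-type nitrogen. Among the measured compounds shown here, no measured step bears on this change: the single step from compound 1 to compound 2 is unreadable, and both values shown sit at the limit (the limit of > 50000 nM in this assay, at which 2 of the 2 values shown sit). With nothing pulling either way, compound 3 is expected to stay near that limit, a step of a number no higher from compound 2 to compound 3 (the limit leaves the size open). The estimate for compound 3 is 50000 nM, within 10000 nM to 150000 nM.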

Compound 3, half-maximal inhibitory concentration: 35400 nM
Compound 3: middle estimate off by 1.4-fold (0.15 log units), on the high side; low and high end bracket the measured number.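

In this assay, 2,4-dichlorophenyl in place of 4-fluorophenyl on the amide-type nitrogen gives an at least 1.4-fold lower number from compound 2 to compound 3 (0.14 log units; that floor lies within the scatter). This floor does not fix the size of the change, so the position is shown only to admit a substituent change that yields a measurable number. Compound 3 is the only compound of the three shown whose value is not a limit: the limit of > 50000 nM in this assay, at which 2 of the 3 values shown sit.

On these data alone, whether a single chlorine would give a measurable number remains open. So does how an amine or a carboxylic acid on this phenyl ring would read in this assay.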